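Trimming the ether chain on a shared chloroquinoline-free core

This account rests on a few compounds, and the source may have more. Where it says the series, first, only, none or still open, it means among the compounds named here.

Three compounds share one core and differ only in the group attached through an oxygen on the aromatic ring. Compound 1 `CCCCCCOc1ccc2c(Cl)ccnc2c1` carries a hexyl chain, compound 2 `CCCCOc1ccc2c(Cl)ccnc2c1` a butyl chain, and compound 3 `Clc1ccnc2cc(OCc3ccccc3)ccc12` a benzyl group. In a functional assay on SK-OV-3 cells (Homo sapiens) for cytotoxicity, read by MTT assay, with a stated time of 48 h (on this read-out higher numbers stand for weaker inhibition and lower numbers for stronger inhibition), compound 1 gives only a limit of the assay, > 10000 nM (the limit of > 10000 nM in this assay, at which 1 of the 3 values shown sits). In this assay compound 2 gives 4130 nM and compound 3 gives 5170 nM. Shortening the chain gave an at least 2.4-fold lower number from compound 1 to compound 2 (0.38 log units; beyond the scatter), and swapping pentyl for phenyl gave an at least 1.9-fold lower number from compound 1 to compound 3 (0.28 log units; that floor lies within the scatter). Between the two true numbers the difference is a 1.3-fold higher number from compound 2 to compound 3 (0.10 log units; within the scatter), so compound 3 and compound 2 sit together, and compound 3 holds the higher of the two numbers only on paper.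

Compound 4 `C=CCOc1ccc2c(Cl)ccnc2c1` is the next member. Its change from compound 3: vinyl in place of phenyl on a saturated chain carbon bound to an oxygen on an aromatic ring. The step from compound 2 to compound 3 is the closest guide, and it stayed within the scatter; the step from compound 1 to compound 3 shows that leaving the long hexyl chain lowers the number. For compound 4 the expectation is therefore a step of about a 1.1-fold lower number from compound 3 to compound 4 (0.06 log units; within the scatter), with no change beyond the scatter, and an estimated value of 4500 nM in this assay, between 2000 nM and 10000 nM.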

Compound 4, half-maximal inhibitory concentration: 4030 nM
For compound 4 the middle estimate is 1.1-fold (0.05 log units) above the measured one, within the range that was stated.
By their numbers in this assay, from the lowest: compounds 4, 2 and 3 (each within the scatter of the next). At a limit, above all of these: compound 1.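

Vinyl in place of phenyl on the saturated chain carbon removes the six-membered aromatic ring, yet in this assay the result stays within the scatter (a 1.3-fold lower number from compound 3 to compound 4 (0.11 log units; within the scatter)), so that ring is not needed to keep the number at this level. Vinyl in place of propyl brings in a double bond outside aromatic rings and also stays within the scatter (a 1.0-fold lower number from compound 2 to compound 4 (0.01 log units; within the scatter)), so compounds 2, 3 and 4 form one group despite their different ether groups. Only the hexyl chain of compound 1 stands apart (an at least 2.4-fold lower number from compound 1 to compound 4 (0.39 log units; beyond the scatter)), and that step is a floor, since compound 1 gave a limit and not a true number: (the limit of > 10000 nM in this assay, at which 1 of the 4 values shown sits).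

As far as these compounds go, whether an amine or a carboxylic acid on this chain would move the number beyond the scatter remains open, as does the behaviour of a pentyl chain, which would lie in length between the butyl chain of compound 2 and the hexyl chain of compound 1. Everything here also rests on this assay alone, so whether these compounds group the same way in other cells is unknown.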